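The source may hold more compounds than are shown below. What is called first, only, known or untested is meant among the compounds shown, and "the series" means these compounds.

Measured in a functional assay on HeLa cells (Homo sapiens) for antiproliferative activity, read by MTT assay, with a stated time of 72 h; a higher number here means a weaker inhibitor, a lower number a stronger inhibitor:
Compound 1 `COc1cc(C(=O)c2sc3ccccc3c2-c2ccccc2)cc(OC)c1OC`: 1900 nM
Compound 2 `COc1cc(C(=O)c2sc3ccccc3c2-c2ccc(SC)cc2)cc(OC)c1OC`: 3500 nM
Compound 3 `COc1ccc(OC)c(-c2c(C(=O)c3cc(OC)c(OC)c(OC)c3)sc3ccccc23)c1`: 10000 nM

Compound 3 has the highest number of the three, which makes it the weakest inhibitor in this small set, and its gaps to both others lie beyond the scatter. Compound 4 `COc1ccc(Nc2c(C(=O)c3cc(OC)c(OC)c(OC)c3)sc3ccccc23)cc1` has not yet been measured. The change that leads to it is (4-methoxyphenyl)amino in place of 2,5-dimethoxyphenyl on an aromatic carbon.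

For the measured compounds named here, three measured steps bear on this change. Two of them bring in the 2,5-dimethoxyphenyl group, and both are modest: a 5.3-fold higher number from compound 1 to compound 3 (0.72 log units; beyond the scatter) and a 2.9-fold higher number from compound 2 to compound 3 (0.46 log units; beyond the scatter). The third, a 1.8-fold higher number from compound 1 to compound 2 (0.27 log units; within the scatter), shows no clear difference. Compound 4 gives up the 2,5-dimethoxyphenyl group, so it may return to the level shared by compound 1 at 1900 nM and compound 2 at 3500 nM. Going by the values given here, no measured compound has an amino link at this place, so that part of the change is untested and the range has to stay wide.

The expected result in this assay is a modest move to a lower number, a 4.0-fold lower number from compound 3 to compound 4 (0.60 log units; beyond the scatter). For compound 4 the estimate is 2500 nM, with an expected range from 400 nM to 10000 nM.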

Compound 4, half-maximal inhibitory concentration: 7700 nM
Compound 4: the middle estimate sits 3.1-fold (0.49 log units) below what was measured; measured number inside the range.
By their numbers in this assay, from the lowest: compounds 1 and 2 (each within the scatter of the next); then compounds 4 and 3 (each within the scatter of the next).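

In this assay, putting (4-methoxyphenyl)amino in place of 2,5-dimethoxyphenyl makes no clear difference, with a 1.3-fold lower number from compound 3 to compound 4 (0.11 log units; within the scatter), so giving up the 2,5-dimethoxyphenyl group does not by itself bring back the level seen with phenyl or 4-(methylsulfanyl)phenyl at this position. Those two groups still give lower numbers, with a 2.2-fold higher number from compound 2 to compound 4 (0.34 log units; beyond the scatter) and a 4.1-fold higher number from compound 1 to compound 4 (0.61 log units; beyond the scatter), so on this aromatic carbon of the five-membered ring with sulfur, the amino-linked group reads like the 2,5-dimethoxyphenyl group and apart from the other two. Nothing available explains why these groups fall out this way.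

On these data alone, the change alters the link and the ring substitution at once, so the effect of each stays open: plain phenylamino and 4-methoxyphenyl joined without the nitrogen would separate the two. A simple amine or a short alkyl chain at the same place would also show whether a second aromatic ring is needed there at all.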